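The source may hold more compounds than are shown below. What is called first, only, known or untested is meant among the compounds shown, and "the series" means these compounds.

Working notes on the series. Compound 2 `Fc1ccc(Nc2cc(Nc3ccc(Oc4ccncc4-c4cccnc4)c(F)c3)ncn2)cc1` gives 710 nM in a functional assay on A549 cells (Homo sapiens) for cytotoxicity, read by MTT assay, with a stated time of 72 h; a lower number here means a stronger inhibitor, a higher number a weaker inhibitor. Compound 1 `Fc1ccc(Nc2cc(Nc3ccc(Oc4ccncc4-c4cccnc4)c(F)c3)ncn2)cc1F` gives 7630 nM in this assay, and the step of an 11-fold higher number from compound 2 to compound 1 (1.03 log units; beyond the scatter) goes with the change (fluoro in place of hydrogen on an aromatic carbon). Compound 3 `Cn1cc(-c2ccccc2)cc(C(=O)Nc2ccc(Oc3ccncc3-c3cccnc3)c(F)c2)c1=O` gives 7600 nM in this assay; the difference between the core of compound 3 and the core of compound 2 is not broken down here.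

Compound 4 `Cn1cc(-c2ccc(F)cc2)cc(C(=O)Nc2ccc(Oc3ccncc3-c3cccnc3)c(F)c2)c1=O` is not yet measured. It differs from compound 3 by fluoro in place of hydrogen on an aromatic carbon, the same kind of change as from compound 2 to compound 1, but the place differs: there the fluoro entered ortho to a fluoro group and meta to a large group, here it enters para to a large group. For the measured compounds named here, the only precedent, the step from compound 2 to compound 1 of an 11-fold higher number from compound 2 to compound 1 (1.03 log units; beyond the scatter), was a large weakening, so a move toward a higher number is expected for compound 4, though a smaller one given the different surroundings, estimated as a 1.6-fold higher number from compound 3 to compound 4 (0.20 log units; within the scatter) in this assay. Compound 4 is expected at 12000 nM, between 4000 nM and 40000 nM.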

Compound 4, half-maximal inhibitory concentration: 8300 nM
Estimate against measurement, compound 4: 1.4-fold (0.16 log units) above; the measured number falls inside the stated range.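

Fluoro in place of hydrogen, here phenyl to 4-fluorophenyl, goes with a 1.1-fold higher number from compound 3 to compound 4 (0.04 log units; within the scatter) in this assay, so this core does not show the large weakening seen on the core of compound 2. The size of the step does not carry over between the two cores: the same change on two cores in this assay, an 11-fold higher number (1.03 log units; beyond the scatter) from compound 2 to compound 1 and a 1.1-fold higher number (0.04 log units; within the scatter) from compound 3 to compound 4, 9.8-fold (0.99 log units) apart, beyond the scatter of two such steps. This rests on one pair per core with the fluoro at a different place in each, so it does not separate the effect of the core from that of the place, and it gives no rule for other cores.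

The compounds shown leave open how a chloro, a methoxy or an amine in place of the fluoro of compound 4 would read in this assay. Also open, as far as these compounds go, is whether a fluoro at other places on the phenyl of compound 3 would give a larger step.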